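Methyl for methoxy on a thioether-linked aryl ring

A few compounds are considered here, and "the series" means these few. Any claim that something is new, unique, unknown or untested is made for them only; others in the source may bear on it.

Measured compounds and their values:
compound 1, `COc1ccccc1Sc1c[nH]c2ccc(Cl)cc12`, gives 17500 nM in an assay on isolated protein for inhibition of Indoleamine 2,3-dioxygenase 1 (Homo sapiens), read by HPLC, with a stated time of 60 min, in the presence of a further agent that is not named here; on this read-out higher numbers stand for weaker inhibition and lower numbers for stronger inhibition.
compound 2, `COc1cccc(Sc2c[nH]c3ccc(Cl)cc23)c1`, gives 21000 nM in this assay.
compound 3, `Cc1ccccc1Sc1c[nH]c2ccc(Cl)cc12`, gives 21000 nM in this assay.

The three compounds share a core, and the difference between the cores of compound 1 and compound 2 is not broken down here. Going from compound 1 to compound 3, the change is methyl in place of methoxy on an aromatic carbon, and it gave a 1.2-fold higher number from compound 1 to compound 3 (0.08 log units; within the scatter) in this assay.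

Compound 4, `Cc1cccc(Sc2c[nH]c3ccc(Cl)cc23)c1`, has not yet been measured. It is reached from compound 2 by methyl in place of methoxy on an aromatic carbon. Among the measured compounds shown here, this is the same kind of change as the one from compound 1 to compound 3, but the place differs: in compound 3 the methyl sits ortho to a large group, in compound 4 it sits meta to a large group.

Because the earlier step of a 1.2-fold higher number from compound 1 to compound 3 (0.08 log units; within the scatter) stayed within the scatter, the expected step from compound 2 to compound 4 in this assay is a 1.1-fold higher number from compound 2 to compound 4 (0.06 log units; within the scatter). Compound 4 is therefore estimated at 24000 nM, between 12000 nM and 48000 nM.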

Compound 4, half-maximal inhibitory concentration: 100000 nM
Compound 4: middle estimate off by 4.2-fold (0.62 log units), on the low side; measured number above the stated range.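

In this assay, methyl in place of methoxy gave a 4.8-fold higher number from compound 2 to compound 4 (0.68 log units; beyond the scatter), which means weaker inhibition, so the small step seen on the core of compound 1 did not carry over to the core of compound 2. Among the compounds shown here, the two steps differ by more than repeated measurements would normally explain: the same change on two cores in this assay, a 1.2-fold higher number (0.08 log units; within the scatter) from compound 1 to compound 3 and a 4.8-fold higher number (0.68 log units; beyond the scatter) from compound 2 to compound 4, 4.0-fold (0.60 log units) apart, beyond the scatter of two such steps This shows that a step measured on one core was a poor guide to the size of the same change on the other, but with only two pairs of compounds it gives neither a reason for the difference nor a general rule for the series.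

The compounds shown leave open how an amine, a hydroxyl or a carboxylic acid in place of the methoxy would read in this assay. They also leave open whether a longer chain, such as ethoxy, would follow the step seen on the core of compound 1 or the larger one seen on the core of compound 2.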